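This account rests on a few compounds, and the source may have more. Where it says the series, first, only, none or still open, it means among the compounds named here.

Compound 1 `CCCCNC(=O)C1C(C(=O)O)[C@@H]2CC[C@H]1O2` is the starting point here, a compound whose shared core carries an amide bearing a butyl group. In an ADME assay on A-431 cells (Homo sapiens) for cytotoxicity, read by MTT assay, with a stated time of 72 h (a lower number here means a stronger inhibitor of growth, a higher number a weaker inhibitor of growth), compound 1 gives 10000 nM. Its two measured companions sit level with it: compound 2 `O=C(O)C1C(C(=O)Nc2ccccc2)[C@H]2CC[C@@H]1O2`, with phenyl in place of butyl on an amide-type nitrogen, gives 10000 nM in this assay, and compound 3 `Cc1cc(C)c(NC(=O)C2C(C(=O)O)[C@@H]3CC[C@H]2O3)c(C)c1` gives 10000 nM. Within the data shown here, the single step that can be read between measured compounds, no change at the digits printed from compound 1 to compound 2 (within the scatter), stays within the scatter, and the values of compound 1 and compound 3 show no difference either.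

Compound 4 `O=C(O)CCCCCCCNC(=O)C1C(C(=O)O)[C@@H]2CC[C@H]1O2` has not yet been measured. It differs from compound 1 by 3-carboxypropyl in place of hydrogen on a saturated chain carbon, four bonds along the chain from an amide-type nitrogen. Among the measured compounds shown here, no measured step touches this part of the chain; the single measured step, no change at the digits printed from compound 1 to compound 2 (within the scatter), changes the group on the amide-type nitrogen itself and is flat, and all three measured compounds rest at the same value. On that basis compound 4 is expected to stay where the others are, with a step of no change at the digits printed from compound 1 to compound 4 (within the scatter) that lies within the scatter. The estimate for compound 4 is therefore 10000 nM, with a range from 5000 nM to 20000 nM.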

Compound 4, concentration for 50% growth inhibition: 10000 nM
Beside the measured number, compound 4's estimate shows no gap at the digits printed, and the stated range covers the measured number.
By their numbers in this assay, from the lowest: compounds 1, 2, 3 and 4 (each within the scatter of the next).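

In this assay, among these compounds, the reading of no change at the digits printed from compound 1 to compound 4 (within the scatter) is the first one that concerns the chain itself, since the earlier step changed only the group on the amide-type nitrogen. Placing 3-carboxypropyl on a saturated chain carbon, four bonds along the chain from an amide-type nitrogen, adds a second carboxylic acid to the compound, and compound 4 at 10000 nM still sits level with compounds 1, 2 and 3, so neither the change on the nitrogen nor this extension of the chain separates any of the four compounds in this assay. Nothing given here bears on why the value stays level.

The compounds shown leave open whether a different group at the same place, such as an amine, a hydroxyl group or a methyl ester in place of the added carboxylic acid, would give a different value. They also leave open whether a change to the free carboxylic acid on the shared core, for example its conversion to an ester or a primary amide, would shift the value in any direction.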